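The compounds below may be only part of what the source reports. "The series", "measured", "known", "first", "only" and "open" are said of these compounds alone.

Measured in a functional assay on MDA-MB-231 cells (Homo sapiens) for cytotoxicity, read by MTT assay, with a stated time of 72 h; a lower number here means a stronger inhibitor, a higher number a weaker inhibitor:
- compound 1 `O=C(CN1CCN(c2nnc(Cc3ccccc3)c3ccccc23)CC1)Nc1c(F)cccc1F`: 5490 nM
- compound 2 `Cc1ccccc1NC(=O)CN1CCN(c2nnc(Cc3ccccc3)c3ccccc23)CC1`: 17300 nM
- compound 3 `O=C(CN1CCN(c2nnc(Cc3ccccc3)c3ccccc23)CC1)Nc1cccc(F)c1`: 3730 nM

Compound 3 stands level with compound 1, with a 1.5-fold lower number from compound 1 to compound 3 (0.17 log units; within the scatter), and well clear of compound 2, with a 4.6-fold lower number from compound 2 to compound 3 (0.67 log units; beyond the scatter).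

Compound 4 `Cc1ccc(NC(=O)CN2CCN(c3nnc(Cc4ccccc4)c4ccccc34)CC2)c(C)c1` carries 2,4-dimethylphenyl in place of 3-fluorophenyl on an amide-type nitrogen. The closest measured group is the 2-methylphenyl of compound 2, at 17300 nM. The step of a 3.2-fold higher number from compound 1 to compound 2 (0.50 log units; beyond the scatter) also points upward on moving to that group. The move away from 3-fluorophenyl is therefore expected to raise the number, with an estimated 2.9-fold higher number from compound 3 to compound 4 (0.47 log units; beyond the scatter). The estimate for compound 4 is 11000 nM, with an expected range of 4000 nM to 28000 nM.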

Compound 4, half-maximal inhibitory concentration: 181000 nM
Compound 4: middle estimate off by 16-fold (1.22 log units), on the low side; the measured number lies above the stated range.
By their numbers in this assay, from the lowest: compounds 3 and 1 (each within the scatter of the next); then compound 2; then compound 4.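

Among the compounds shown here, replacing hydrogen with methyl on an aromatic carbon of the aryl group on the amide-type nitrogen gives a 10-fold higher number from compound 2 to compound 4 (1.02 log units; beyond the scatter) in this assay, so a single added methyl here outweighs every step among the earlier compounds. The 2,4-dimethylphenyl group also stands far from both fluorinated groups, with a 49-fold higher number from compound 3 to compound 4 (1.69 log units; beyond the scatter) and a 33-fold higher number from compound 1 to compound 4 (1.52 log units; beyond the scatter). No available evidence bears on what lies behind this rise.

On these data alone, whether 4-methylphenyl or 4-chlorophenyl on the same nitrogen would give a similar rise remains open.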